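Moving the chlorine on a benzyl triazole arm

This account rests on a few compounds, and the source may have more. Where it says the series, first, only, none or still open, it means among the compounds named here.

Three related compounds have been examined in a functional assay on MCF7 cells (Homo sapiens) for cytotoxicity, read by MTT assay, with a stated time of 24 h; a higher number here means a weaker inhibitor, a lower number a stronger inhibitor. Compound 3 `O=C1/C(=C/c2ccccc2F)CN(C(=S)SCc2cn(Cc3cccc(Cl)c3)nn2)C/C1=C\c1ccccc1F` in this assay reaches only the limit > 100000 nM. Compound 1 `O=C1/C(=C/c2ccccc2F)CN(C(=S)SCc2cn(Cc3ccccc3Cl)nn2)C/C1=C\c1ccccc1F` differs from it by 2-chlorophenyl in place of 3-chlorophenyl on a saturated chain carbon bound to an aromatic nitrogen and gives 78700 nM in this assay, a step of an at least 1.2-fold lower number from compound 3 to compound 1 (0.10 log units; that floor lies within the scatter). Compound 2 `COc1ccc(/C=C2\CN(C(=S)SCc3cn(Cc4cccc(Cl)c4)nn3)C/C(=C\c3ccc(OC)cc3)C2=O)cc1` gives 32000 nM in this assay; how its core differs from the core of compound 3 is not broken down here. Compound 4 `COc1ccc(/C=C2\CN(C(=S)SCc3cn(Cc4ccccc4Cl)nn3)C/C(=C\c3ccc(OC)cc3)C2=O)cc1` carries the same change that turned compound 3 into compound 1, namely (2-chlorophenyl in place of 3-chlorophenyl on a saturated chain carbon bound to an aromatic nitrogen). Since an at least 1.2-fold lower number from compound 3 to compound 1 (0.10 log units; that floor lies within the scatter) is only a floor lying within the scatter, a step of the same small size is expected in this assay, a 1.2-fold lower number from compound 2 to compound 4 (0.09 log units; within the scatter). Compound 4 is therefore estimated at 26000 nM, with the expected range running from 10000 nM to 70000 nM.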

Compound 4, half-maximal inhibitory concentration: > 100000 nM
Compound 4: no number, only a limit; the forecaster's own chance of this, stated with the estimate: 5%; at least 3.8-fold (0.58 log units) between middle value and limit.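

In this assay compound 4 gives > 100000 nM, which is a limit and not a number. Even so, the change from 3-chlorobenzyl to 2-chlorobenzyl on the core of compound 2 gives an at least 3.1-fold higher number from compound 2 to compound 4 (0.49 log units; beyond the scatter), so its effect did not carry over unchanged from one core to the other: the same change on two cores in this assay, an at least 1.2-fold lower number (0.10 log units; that floor lies within the scatter) from compound 3 to compound 1 and an at least 3.1-fold higher number (0.49 log units; beyond the scatter) from compound 2 to compound 4, at least 3.9-fold (0.59 log units) apart, beyond the scatter of two such steps. This does not give the true size of either step or a rule for the series, as each step rests on a limit and only two cores are shown: the limit of > 100000 nM in this assay, at which 2 of the 4 values shown sit.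

The compounds shown leave open how a plain benzyl arm without chlorine, or bromine in place of the chlorine, would behave on either core. From the compounds shown here alone, how the same change would behave on a third core also stays open.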